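The compounds below may be only part of what the source reports. "The series", "measured", "known", "first", "only" and "open" are said of these compounds alone.

Compound 1 `CNC(=O)/C=C/c1ccncc1-c1ccc2ccccc2c1`: 12.4 nM
Compound 2 `O=C(O)CCNC(=O)/C=C/c1ccncc1-c1ccc2ccccc2c1`: 870 nM
Compound 3 `O=C(/C=C/c1ccncc1-c1ccc2ccccc2c1)N1CCOCC1`: 60.3 nM

All three share one core and differ only in the chain that carries the carbonyl. In an assay on a protein complex for inhibition of CDK8/Cyclin C (Homo sapiens), with a stated time of 1 h (a lower number here means a stronger inhibitor, a higher number a weaker inhibitor), compound 1 gives the lowest number of the three; the other two stand further away, compound 2 by far the most, as a 70-fold higher number from compound 1 to compound 2 (1.85 log units; beyond the scatter) shows. Compound 4 `COC(=O)CCc1ccncc1-c1ccc2ccccc2c1` alters compound 1 in one place: 2-(methoxycarbonyl)ethyl in place of 2-(methylcarbamoyl)ethenyl on an aromatic carbon. The amide hydrogen donor and one double bond are lost, and an ester takes the place of the amide. The step that bears most on this is a 4.9-fold higher number from compound 1 to compound 3 (0.69 log units; beyond the scatter), where the donor was also removed. A weakening beyond the scatter is therefore expected, a 20-fold higher number from compound 1 to compound 4 (1.30 log units; beyond the scatter). Compound 4 is estimated at 250 nM, within 60 nM to 1500 nM.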

Compound 4, half-maximal inhibitory concentration: 259 nM
Compound 4: the middle estimate sits 1.0-fold (0.02 log units) below what was measured; measured number inside the range.
By their numbers in this assay, from the lowest: compound 1; then compound 3; then compound 4; then compound 2.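

The step of a 21-fold higher number from compound 1 to compound 4 (1.32 log units; beyond the scatter) in this assay is the first change shown that reaches the link between the carbonyl and the aromatic carbon, since compounds 1, 2 and 3 all keep the double bond. Both groups have 6 heavy atoms, yet the double bond, the amide hydrogen and the amide itself all change together, so this step cannot be assigned to any one of them. No evidence here accounts for the weakening.

Still open, from the compounds shown here alone, is how a saturated chain ending in the methyl amide would compare, and how the double bond carrying a methyl ester would. A carboxylic acid directly on this chain also remains to be placed.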